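The compounds below may be only part of what the source reports. "The series", "measured", "known", "first", "only" and "open" are said of these compounds alone.

Of the compounds shown here, three have values so far in a functional assay on PC-3 cells (Homo sapiens) for antiproliferative activity, read by MTT assay, with a stated time of 72 h (on this read-out higher numbers stand for weaker inhibition and lower numbers for stronger inhibition), and they are these.

compound 1 `O=C(N/N=C/c1ccc(Br)cc1)Nc1ccc(Oc2ccnc3[nH]ccc23)c(F)c1` gives 920 nM
compound 2 `CCN(CC)CCn1cccc1/C=N/NC(=O)Nc1ccc(Oc2ccnc3[nH]ccc23)cc1` gives 1370 nM
compound 3 `O=C(N/N=C/c1cccn1CCCN1CCCCC1)Nc1ccc(Oc2ccnc3[nH]ccc23)c(F)c1` gives 2840 nM

Compound 2 at 1370 nM cannot be told apart from compound 1 at 920 nM given the usual scatter, whereas compound 3 at 2840 nM stands higher than compound 2 by a margin beyond the scatter.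

Compound 4 `CN1CCN(CCCn2cccc2/C=N/NC(=O)Nc2ccc(Oc3ccnc4[nH]ccc34)cc2)CC1` has not yet been measured in this assay and is the next case. Against compound 2 it carries this change: (4-methylpiperazin-1-yl)methyl in place of diethylamino on a saturated chain carbon, two bonds along the chain from an aromatic nitrogen that is, (4-methylpiperazin-1-yl)methyl in place of diethylamino on a saturated chain carbon, two bonds along the chain from an aromatic nitrogen.

Going by the values given here, no measured pair isolates this change, so the expectation rests on thin evidence. The closest guide is compound 3 at 2840 nM with a ring at the end of its side chain, although it differs from compound 4 in more than one place. A small move towards a higher number, meaning somewhat weaker inhibition, is therefore expected. The estimated step of a 1.4-fold higher number from compound 2 to compound 4 (0.14 log units; within the scatter) is one that may well stay within the scatter. For compound 4 the estimated value is 1900 nM with 700 nM to 5000 nM as the expected range.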

Compound 4, half-maximal inhibitory concentration: 3740 nM
Beside the measured number, compound 4's estimate is 2.0-fold (0.29 log units) below it; the measured number falls inside the stated range.
By their numbers in this assay, from the lowest: compounds 1 and 2 (each within the scatter of the next); then compounds 3 and 4 (each within the scatter of the next).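

In this assay, going by these compounds alone, putting (4-methylpiperazin-1-yl)methyl in place of diethylamino, on a saturated chain carbon, two bonds along the chain from an aromatic nitrogen, gives a 2.7-fold higher number from compound 2 to compound 4 (0.44 log units; beyond the scatter), the first comparison in this set in which only one place differs. It shows that the assay responds to what stands at this position and that, for this exchange, the response is towards weaker inhibition, although the size of the step is modest. Nothing shown here accounts for the step, and no measurement of any property of these compounds accompanies it.

The exchange brings in the six-membered non-aromatic ring and also, read one bond further out, turns 2-(diethylamino)ethyl into 3-(4-methylpiperazin-1-yl)propyl, so the compounds shown cannot separate the ring from the longer chain; a 3-(diethylamino)propyl or a 2-(4-methylpiperazin-1-yl)ethyl group on the same core would pull the two apart. Going by these compounds, it also remains open how other end groups, such as a morpholine ring or a dimethylamino group, would read at this position, and whether the same exchange gives a similar step on a core carrying fluorine, as in compound 3.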